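The source may report more compounds than this note shows. Statements on the series, on what has been measured and on what is new or still open speak of the compounds shown alone.

Compound 1 `CCOC(=O)C1=C(C)N/C(=C/c2cc(C)n(-c3cccc(C(F)(F)F)c3)c2C)C1=O` is the reference point of this account. In an ADME assay on microsomes from liver (Mus musculus) for metabolic stability, read by LC-MS, tested at 1 uM (on this read-out higher numbers stand for fast clearance and lower numbers for slow clearance), compound 1 gives 97 mL.min-1.g-1, the largest of the three numbers recorded, although neither of the other two compounds lies beyond the scatter of it. Compound 2 `CCOC(=O)C1=C(C)N/C(=C/c2cc(C)n(-c3ccc(OC)cc3)c2C)C1=O` gives 54 mL.min-1.g-1 in this assay, and compound 3 `CCOC(=O)C1=C(C)N/C(=C/c2cc(C)n(-c3ccc(N(C)C)cc3)c2C)C1=O` gives 56 mL.min-1.g-1. The two changes already made on the aromatic nitrogen of compound 1 gave a 1.8-fold lower number from compound 1 to compound 2 (0.25 log units; within the scatter) and a 1.7-fold lower number from compound 1 to compound 3 (0.24 log units; within the scatter), and the exchange of one para group for the other gave a 1.0-fold higher number from compound 2 to compound 3 (0.02 log units; within the scatter); none of these moved the number beyond the scatter.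

Compound 4 `CCOC(=O)C1=C(C)N/C(=C/c2cc(C)n(-c3ccncc3)c2C)C1=O` is the next compound in this line. It differs from compound 1 in one place: pyridin-4-yl in place of 3-(trifluoromethyl)phenyl on an aromatic nitrogen. Going by the values given here, the steps that bear on it are those from compound 1 to compound 2 and from compound 1 to compound 3, both replacements of the same 3-(trifluoromethyl)phenyl on the same nitrogen, and both stayed within the scatter. On that basis no step beyond the scatter is expected for compound 4 in this assay, with at most a slight drift in the direction seen for compound 2 and compound 3, because of a 1.8-fold lower number from compound 1 to compound 2 (0.25 log units; within the scatter) and a 1.7-fold lower number from compound 1 to compound 3 (0.24 log units; within the scatter). Compound 4 is therefore estimated at 70 mL.min-1.g-1, with a range from 35 mL.min-1.g-1 to 140 mL.min-1.g-1, meaning an expected 1.4-fold lower number from compound 1 to compound 4 (0.14 log units; within the scatter).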

Compound 4, intrinsic clearance in microsomes: 61 mL.min-1.g-1
For compound 4 the middle estimate is 1.1-fold (0.06 log units) above the measured one; the measured number falls inside the stated range.
By their numbers in this assay, from the lowest: compounds 2, 3, 4 and 1 (each within the scatter of the next).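

Going by these compounds alone, compound 4 is the first compound here in which the ring on the aromatic nitrogen holds a hetero atom: pyridin-4-yl, with one hydrogen-bond acceptor and fewer heavy atoms, takes the place of the carbon-only 3-(trifluoromethyl)phenyl, and in this assay this gives a step that stays within the scatter (a 1.6-fold lower number from compound 1 to compound 4 (0.20 log units; within the scatter)). The comparisons with the two substituted phenyl compounds also stay within the scatter (a 1.1-fold higher number from compound 3 to compound 4 (0.04 log units; within the scatter); a 1.1-fold higher number from compound 2 to compound 4 (0.05 log units; within the scatter)), so at this position, across these four compounds, neither the hetero atom in the ring nor the loss of the substituent on the ring moves the number beyond the scatter. Nothing available gives a measured basis for explaining the size of these steps.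

These compounds all carry an aromatic six-membered ring on this nitrogen, so they leave open what a saturated ring such as piperidine, a longer alkyl chain or a phenyl ring bearing a carboxylic acid would do there. They also leave open whether changes elsewhere on the shared core, such as at the ethyl ester, would move the number beyond the scatter.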